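Hydroxycarbamoyl chain extension: from compound 2 to compound 3

The source may hold more compounds than are shown below. What is called first, only, known or untested is meant among the compounds shown, and "the series" means these compounds.

In a functional assay on HepG2 cells (Homo sapiens) for antiproliferative activity, read by MTT assay, with a stated time of 96 h (a lower number here means a stronger inhibitor of growth, a higher number a weaker inhibitor of growth), compound 1 `O=C(CCNC(=O)c1cc(-c2ccc(F)cc2)[nH]n1)NO` gives 76000 nM and compound 2 `O=C(CCCNC(=O)c1cc(-c2ccc(F)cc2)[nH]n1)NO` gives 88000 nM. Compound 2 therefore stands level with compound 1, the only other measured point. Among the measured compounds shown here, the single measured step, a 1.2-fold higher number from compound 1 to compound 2 (0.06 log units; within the scatter), is (hydroxycarbamoyl)methyl in place of hydroxycarbamoyl and lies within the scatter.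

Compound 3 `O=C(CCCCCCNC(=O)c1cc(-c2ccc(F)cc2)[nH]n1)NO` carries 3-(hydroxycarbamoyl)propyl in place of hydroxycarbamoyl on a saturated chain carbon, three bonds along the chain from an amide-type nitrogen. This replacement is larger than the one already measured, so that step is only a weak guide. It shows no change for a small extension but cannot say whether the flat trend holds for a chain of this length. For the measured compounds named here, the series contains no measured compound with so long a chain, and two flat points do not fix a trend. A move towards a lower number in this assay is expected, but tentatively. The estimated step is a 7.3-fold lower number from compound 2 to compound 3 (0.87 log units; beyond the scatter). For compound 3 the expected value is 12000 nM, with an estimated range of 2500 nM to 70000 nM.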

Compound 3, concentration for 50% growth inhibition: 23200 nM
The estimate for compound 3 lay 1.9-fold (0.29 log units) below the measured number; low and high end bracket the measured number.
By their numbers in this assay, from the lowest: compound 3; then compounds 1 and 2 (each within the scatter of the next).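

In this assay, lengthening the chain at this position now has a readable effect: 3-(hydroxycarbamoyl)propyl in place of hydroxycarbamoyl gives a 3.8-fold lower number from compound 2 to compound 3 (0.58 log units; beyond the scatter), and 4-(hydroxycarbamoyl)butyl in place of hydroxycarbamoyl gives a 3.3-fold lower number from compound 1 to compound 3 (0.52 log units; beyond the scatter). Both steps are modest but beyond the scatter, whereas the smaller extension, a 1.2-fold higher number from compound 1 to compound 2 (0.06 log units; within the scatter), is not, so the three compounds do not show a steady change with chain length: compounds 1 and 2 stand level, and only compound 3 departs from them. No information is available that would account for this difference in response to chain length.

The compounds shown leave open whether a longer chain than that of compound 3 would lower the number further or reverse the step, and at what chain length the departure from compounds 1 and 2 first appears. Also open, on these data alone, is whether a carboxylic acid in place of the terminal hydroxycarbamoyl group on the chain of compound 3 would give a number close to that of compound 3 (23200 nM).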